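The compounds below may be only part of what the source reports. "The series", "measured", "known", "first", "only" and "open" are said of these compounds alone.

Compound 1 `CN1CC(=O)N(Cc2ccc(C(=O)NO)cc2)C1=O`, compound 2 `CC1(c2ccccc2)NC(=O)N(Cc2ccc(C(=O)NO)cc2)C1=O` and compound 3 `CCCC1(c2ccccc2)NC(=O)N(Cc2ccc(C(=O)NO)cc2)C1=O` share one core and differ only at a single saturated ring carbon. In an assay on isolated protein for inhibition of protein deacetylase HDAC6 (Homo sapiens), read by fluorescence, with stated times of 10 min and 2 h (a lower number here means a stronger inhibitor, a higher number a weaker inhibitor), compound 1 gives 119 nM, compound 2 gives 74.9 nM and compound 3 gives 50.9 nM. Compound 3 thus carries the lowest number of the three; its gap to compound 1 lies beyond the scatter, whereas its gap to compound 2 lies within it. Compound 4 `O=C(NO)c1ccc(CN2C(=O)NC(Cc3ccccc3)(c3ccccc3)C2=O)cc1` differs from compound 3 by phenyl in place of ethyl on a saturated chain carbon bound to a saturated ring carbon. Among the measured compounds shown here, only one measured step touches this place: a 1.5-fold lower number from compound 2 to compound 3 (0.17 log units; within the scatter), a change that stayed within the scatter. For the measured compounds named here, that step is the sole guide, and it suggests growth at this chain carbon does little to the number. The change from compound 3 to compound 4 is therefore expected to be small, at most a modest move toward a lower number, estimated as a 1.3-fold lower number from compound 3 to compound 4 (0.10 log units; within the scatter). For compound 4 the expected value in this assay is 40 nM, within a range from 15 nM to 120 nM.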

Compound 4, half-maximal inhibitory concentration: 71.9 nM
The estimate for compound 4 lay 1.8-fold (0.25 log units) below the measured number, and the stated range covers the measured number.
By their numbers in this assay, from the lowest: compounds 3, 4, 2 and 1 (each within the scatter of the next, the first and the last beyond it).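

In this assay, among the compounds shown here, the step of a 1.4-fold higher number from compound 3 to compound 4 (0.15 log units; within the scatter) shows that a six-membered aromatic ring of carbon only can replace ethyl on this saturated chain carbon while the number stays within the scatter, a change much larger than any the earlier compounds had tested here. The step of a 1.0-fold lower number from compound 2 to compound 4 (0.02 log units; within the scatter) shows the same for phenyl in place of hydrogen, so hydrogen, ethyl and phenyl at this place all give numbers within the scatter of one another. Nothing available explains why the number hardly responds to these changes.

Going by these compounds, all three groups at this place contain carbon and hydrogen only, so it remains open whether an amine or a carboxylic acid there would shift the number beyond the scatter. On these data alone, it also remains open whether a longer chain ending in phenyl would be accommodated as readily as benzyl.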